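Tetrazolyl in place of carboxy on the compound 2 core

The source may hold more compounds than are shown below. What is called first, only, known or untested is meant among the compounds shown, and "the series" means these compounds.

All three measured compounds were tested in a functional assay on the whole organism (strain Sprague-Dawley) for inhibition, with Rattus norvegicus as the target (on this read-out higher numbers stand for an effect only at larger amounts of compound and lower numbers for an effect already at smaller amounts), and none returned a number. Compound 1 `O=C(O)c1cnc2c(F)cccc2c1` gives only a limit, > 25 mg/kg. Compound 2 `O=C(O)c1cnc2cc(C(F)(F)F)ccc2c1` likewise gives only a limit, > 25 mg/kg. Compound 3 `O=c1c(-c2nn[nH]n2)c[nH]c2c(F)ccc(F)c12`, built on a different core, also returns only a limit, > 0.156 mg/kg. Compound 2 thus stands at the limit of > 25 mg/kg in this assay, at which 2 of the 3 values shown sit, and the remaining value sits at the limit of > 0.156 mg/kg in this assay, at which 1 of the 3 values shown sits. Among the compounds with values here, no pair of measured compounds differs in a single place, so no measured step is available to set the size of a structural change against.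

Compound 4 `FC(F)(F)c1ccc2cc(-c3nn[nH]n3)cnc2c1` is the next compound to be measured in this assay . It differs from compound 2 in one place: 2H-tetrazol-5-yl in place of carboxy on an aromatic carbon. With compound 2 known only as a limit, the data give no anchor for the direction or size of this change; a move in either direction, or none beyond the scatter, is open. The expected step is therefore written as an at least 1.2-fold lower number from compound 2 to compound 4 (0.09 log units; that floor lies within the scatter), with wide uncertainty. Compound 4 is expected to give 20 mg/kg in this assay , with a range from 3 mg/kg to 50 mg/kg, and a fair chance that only a limit is reported again.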

Compound 4, minimum effective dose: < 10 mg/kg
Compound 4: a limit, no number (the forecaster's own chance of this, stated with the estimate: 55%); at least 2.0-fold (0.30 log units) between middle value and limit.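

Replacing carboxy with 2H-tetrazol-5-yl on the aromatic carbon two atoms from the ring nitrogen gives, in this assay, an at least 2.5-fold lower number from compound 2 to compound 4 (0.39 log units; beyond the scatter). Within the data shown here, this is the first single-place step, and it shows that carboxy is not needed at this position for an effect on this read-out, whereas the earlier compounds offered no pair from which to judge the position at all. The size of the step remains a floor, since both ends are limits and compound 4 alone has a limit of this kind: the limit of < 10 mg/kg in this assay, at which 1 of the 4 values shown sits.

Compound 3 also carries a 2H-tetrazol-5-yl group, but on a different core, so it differs from compound 4 in more than one place and its limit cannot be set against the step. Going by these compounds, how far the true value of compound 4 lies under its limit stays open, as does whether a carboxamide or a sulfonamide in place of carboxy on the shared core would lower the number in the same way, or whether the step would hold without the trifluoromethyl group.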